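A few compounds are considered here, and "the series" means these few. Any claim that something is new, unique, unknown or untested is made for them only; others in the source may bear on it.

From the compounds shown here alone, in a functional assay on PC-3 cells (Homo sapiens) for inhibition, read by sulforhodamine B assay, with a stated time of 48 h, tested at 50 uM (on this read-out higher numbers stand for more inhibition of growth at the one concentration tested and lower numbers for less inhibition of growth), compound 1 (`COc1cc(/C=C/C(=O)/C=C/c2cccc3ccccc23)ccc1OCc1cn(CCCCCOc2cc(=O)oc3ccccc23)nn1`) has no number: it was reported as "not active" (no number reported), so its exact place on the scale stays open. Among the compounds with values here, the only number so far comes from compound 2 (`COc1cc(/C=C/C(=O)/C=C/c2cccs2)ccc1OCc1cn(CCOc2cc(=O)oc3ccccc23)nn1`), which gives 12%. Compound 3 (`COc1cc(/C=C/C(=O)/C=C/c2ccco2)ccc1OCc1cn(CCCCCOc2cc(=O)oc3ccccc23)nn1`) has not yet been measured. It differs from compound 1 in one place: furan-2-yl in place of naphthalen-1-yl on a double-bonded chain carbon bound to a double-bonded chain carbon. In words, furan-2-yl stands in place of naphthalen-1-yl on a double-bonded chain carbon bound to a double-bonded chain carbon. Within the data shown here, no measured pair shows what this swap does, so the expected step in this assay is a small upward one, probably no larger than the usual scatter of repeated measurements. Compound 3 could again be reported without a number. Weak growth inhibition is expected, resting on compound 2 at 12%. The estimated value for compound 3 is 12%, with a range of 0% to 30%.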

Compound 3, percent growth inhibition at one concentration: "not active" (no number reported)
No number was reported for compound 3, so the estimate cannot be set against anything.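

Neither compound 1 nor compound 3 carries a number in this assay so no step can be read between them. From the compounds shown here alone, what changing naphthalen-1-yl to furan-2-yl does to growth inhibition stays open. Nothing shown offers an explanation for this result.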